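Methyl in Place of Methoxy: What to Expect for Compound 4

A few compounds are considered here, and "the series" means these few. Any claim that something is new, unique, unknown or untested is made for them only; others in the source may bear on it.

Compound 1, `CCc1ccc(-c2nn3cc(-c4cccc(N)c4)nc3s2)cc1`: 22000 nM in a functional assay on CCRF-CEM cells (Homo sapiens) for inhibition, read by cell counting, with a stated time of 3 days; on this read-out higher numbers stand for weaker inhibition and lower numbers for stronger inhibition
Compound 2, `Nc1cccc(-c2cn3nc(Cc4ccccc4)sc3n2)c1`: 37000 nM in this assay
Compound 3, `COc1ccc(-c2nn3cc(-c4cccc(N)c4)nc3s2)cc1`: >= 250000 nM in this assay

Among the three measured compounds, compound 3 stands apart. Its reading of >= 250000 nM in this assay is a limit of the assay and not a number, namely (the limit of >= 250000 nM in this assay, at which 1 of the 3 values shown sits). Compound 1 and compound 2 both give numbers, and the change from compound 1 to compound 3, methoxy in place of ethyl on an aromatic carbon, brought an at least 11-fold higher number from compound 1 to compound 3 (1.05 log units; beyond the scatter).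

Compound 4, `Cc1ccc(-c2nn3cc(-c4cccc(N)c4)nc3s2)cc1`, is the next member of this series. It differs from compound 3 by methyl in place of methoxy on an aromatic carbon. For the measured compounds named here, no measured pair shows exactly this exchange, so the only step that bears on it is the one from compound 1 to compound 3, which removed an ethyl and installed a methoxy and was large. Compound 4 carries a methyl where compound 1 carries an ethyl; its group is closer in kind to that of compound 1 than to the methoxy of compound 3. Compound 4 is therefore expected to show an at least 5.5-fold lower number from compound 3 to compound 4 (0.74 log units; beyond the scatter) in this assay, and its estimated value is 45000 nM with a range from 15000 nM to 250000 nM.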

Compound 4, half-maximal inhibitory concentration: 5900 nM
Compound 4: the middle estimate sits 7.6-fold (0.88 log units) above what was measured, outside the stated range (below it).
By their numbers in this assay, from the lowest: compound 4; then compounds 1 and 2 (each within the scatter of the next). At a limit, above all of these: compound 3.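

At the aromatic carbon para to a large group, methyl in place of methoxy brings an at least 42-fold lower number from compound 3 to compound 4 (1.62 log units; beyond the scatter) in this assay, which shows that the earlier loss on moving to methoxy can also be reversed with a group other than ethyl. That step has compound 3 at one end, and the reading of compound 3 is a limit and not a number: the limit of >= 250000 nM in this assay, at which 1 of the 4 values shown sits. The result also shows that the two alkyl groups at this position are not interchangeable, since the change from ethyl to methyl brings a 3.7-fold lower number from compound 1 to compound 4 (0.57 log units; beyond the scatter), while 4-methylphenyl in place of benzyl brings a 6.3-fold lower number from compound 2 to compound 4 (0.80 log units; beyond the scatter), so that compound 4 has the lowest number of the series shown.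

With only methyl, ethyl and methoxy compared at this position on the shared core, the compounds shown cannot tell whether the number would keep falling with a still smaller substituent such as fluorine or would rise again. As far as these compounds go, what a hydroxyl, an amine or a longer chain such as propyl would do in that place also remains open.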